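The source may hold more compounds than are shown below. What is called first, only, known or untested is meant among the compounds shown, and "the series" means these compounds.

Compound 1 `CCCn1cc(C(=O)NCc2ccc(OC)cc2)c(=O)c2cc(F)c(N3CCC(C(N)=O)CC3)cc21`: 41400 nM
Compound 2 `CCCCn1cc(C(=O)NCc2ccccc2)c(=O)c2cc(F)c(-c3ccccc3)cc21`: > 100000 nM, a limit
Compound 3 `CCn1cc(C(=O)O)c(=O)c2ccc(C(F)(F)F)cc21`: > 100000 nM, a limit

These values come from an ADME assay on J774.1 cells (Mus musculus) for cytotoxicity, read by resazurin assay, with a stated time of 48 h; a lower number here means a stronger inhibitor, a higher number a weaker inhibitor. Compound 1 is the only one of the three with an exact number. Compound 2 stands at the limit of > 100000 nM in this assay, at which 2 of the 3 values shown sit, so it is a limit of the assay and not a number.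

Compound 4 `CCCCn1cc(C(=O)NCc2ccccc2)c(=O)c2cc(F)c(N(C)Cc3ccccc3)cc21` keeps the rest of compound 2 but has benzyl(methyl)amino in place of phenyl on an aromatic carbon. Among the compounds with values here, no measured pair shows this change alone, so any forecast is uncertain. Compound 1 offers a weak hint, as it also has a nitrogen attached at that carbon and gives 41400 nM, although it differs from compound 2 elsewhere too.

In this assay, a modest move toward a lower number is therefore expected, and compound 4 could still reach the limit. The expected change is an at least 1.6-fold lower number from compound 2 to compound 4 (0.22 log units; that floor lies within the scatter). For compound 4 the estimated value is 60000 nM, with an expected range of 20000 nM to 100000 nM.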

Compound 4, half-maximal inhibitory concentration: 86000 nM
Compound 4: the middle estimate sits 1.4-fold (0.16 log units) below what was measured, and the stated range covers the measured number.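

In this assay, within the data shown here, this position now has a comparison in which only one group changes: benzyl(methyl)amino in place of phenyl on this aromatic carbon, ortho to a fluoro group, gives an at least 1.1-fold lower number from compound 2 to compound 4 (0.06 log units; that floor lies within the scatter). This shows that the swap can yield an exact reading in this assay, but not that it truly lowers the number, since the printed floor does not go beyond the scatter. As far as these compounds go, the true size of the step stays unknown because compound 2 carries a limit of the assay and not a number: the limit of > 100000 nM in this assay, at which 2 of the 4 values shown sit.

From the compounds shown here alone, what stays open is whether the attached nitrogen or the benzyl part of the new group accounts for the exact reading. A smaller group on the same carbon, such as dimethylamino, would help to separate the two.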